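Cyclopropyl for methyl on a sulfonyl sulfur

The compounds below may be only part of what the source reports. "The series", "measured", "known", "first", "only" and "open" are said of these compounds alone.

Among the compounds with values here, in an ADME assay on a cell-free system (plasma, Mus musculus) for protein binding (on this read-out lower numbers stand for a smaller free fraction and higher numbers for a larger free fraction), compound 2 (`CC(C)COc1ccc(-c2cn(C)c3cc(C(=O)NS(C)(=O)=O)c(F)cc23)cn1`) gives 0.014 and stands highest of the two compounds measured so far. Compound 1 (`CC(C)COc1ncc(-c2cn(C)c3cc(C(=O)NS(=O)(=O)C4CC4)c(F)cc23)cc1Cl`) gives 0.002 on the same scale, a gap that lies beyond the scatter. Compound 3 (`CC(C)COc1ccc(-c2cn(C)c3cc(C(=O)NS(=O)(=O)C4CC4)c(F)cc23)cn1`) has cyclopropyl in place of methyl on a sulfonyl sulfur and is otherwise the same as compound 2. Within the data shown here, no measured pair shows this change alone. Among the measured compounds shown here, the only guide is compound 1, which also carries cyclopropyl on a sulfonyl sulfur and differs elsewhere from compound 3. Compound 1 gives 0.002 as its low reading. The expected step in this assay is a 1.8-fold lower number from compound 2 to compound 3 (0.24 log units; within the scatter) toward a smaller free fraction, probably still within the scatter. For compound 3 the estimated value is 0.008 with an expected range from 0.004 to 0.015 when it is measured.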

Compound 3, unbound fraction: 0.006
Beside the measured number, compound 3's estimate is 1.3-fold (0.12 log units) above it, and the stated range covers the measured number.
By their numbers in this assay, from the lowest: compound 1; then compound 3; then compound 2.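

Within the data shown here, compound 3 gives the first reading of this change on its own: in this assay, cyclopropyl in place of methyl on a sulfonyl sulfur brings a 2.3-fold lower number from compound 2 to compound 3 (0.37 log units; beyond the scatter), a modest step but one beyond the scatter. It also separates a second place, as hydrogen in place of chloro on an aromatic carbon brings a 3.0-fold higher number from compound 1 to compound 3 (0.48 log units; beyond the scatter), so the gap between compound 1 and compound 2 does not rest on the sulfonyl substituent alone. Nothing in the data gives a reason for either step.

The compounds shown leave open whether an ethyl or isopropyl group on the sulfonyl sulfur would give a reading nearer to compound 2 or to compound 3. They also leave open how fluoro or methoxy in place of chloro on that aromatic carbon would read.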